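A few compounds are considered here, and "the series" means these few. Any claim that something is new, unique, unknown or untested is made for them only; others in the source may bear on it.

Measured so far:
- compound 1, `CN1CCC(S(=O)(=O)c2ccc(CNC(=O)N3Cc4ccncc4C3)cc2)CC1`: 48 nM
- compound 2, `O=C(NCc1ccc(S(=O)(=O)N2CC3(CCOCC3)C2)cc1)N1Cc2ccncc2C1`: 20 nM

Going by the values given here, compound 2 holds the lowest of the two numbers in an assay on isolated protein for inhibition of Nicotinamide phosphoribosyltransferase (Homo sapiens), read by mass spectrometry, with stated times of 15 min and 30 min; on this read-out lower numbers stand for stronger inhibition and higher numbers for weaker inhibition; its only neighbour on this read-out is compound 1, and the step of a 2.4-fold lower number from compound 1 to compound 2 (0.38 log units; beyond the scatter) sets the two apart by more than the scatter.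

Compound 3, `O=C(NCc1ccc(S(=O)(=O)N2CCC(N3CCCC3)CC2)cc1)N1Cc2ccncc2C1`, differs from compound 2 at one place: a group of 11 heavy atoms (9 carbon, 2 nitrogen; one five-membered non-aromatic ring with 1 hetero atom, one six-membered non-aromatic ring with 1 hetero atom) in place of a group of 9 heavy atoms (7 carbon, 1 nitrogen, 1 oxygen; one four-membered non-aromatic ring with 1 hetero atom, one six-membered non-aromatic ring with 1 hetero atom), on a sulfonyl sulfur. Among the compounds with values here, the one measured step that touches the same position, a 2.4-fold lower number from compound 1 to compound 2 (0.38 log units; beyond the scatter), shows that exchanging the group on the sulfonyl sulfur shifts the number by a modest amount only. Compound 3 shares with compound 1 a six-membered ring bearing a nitrogen on the sulfonyl sulfur, and with compound 2 the sulfonamide link; nothing measured separates these two features. A step of modest size is therefore expected, with no firm direction, most likely landing between the numbers of compound 1 and compound 2.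

Compound 3 is estimated at 30 nM in this assay, a range of 12 nM to 75 nM, which means an expected step of a 1.5-fold higher number from compound 2 to compound 3 (0.18 log units; within the scatter).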

Compound 3, half-maximal inhibitory concentration: 7.4 nM
For compound 3 the middle estimate is 4.1-fold (0.61 log units) above the measured one; the measured number lies below the stated range.
By their numbers in this assay, from the lowest: compound 3; then compound 2; then compound 1.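

In this assay the group on the sulfonyl sulfur has more range than the first pair suggested: a 2.7-fold lower number from compound 2 to compound 3 (0.43 log units; beyond the scatter) adds to the earlier 2.4-fold lower number from compound 1 to compound 2 (0.38 log units; beyond the scatter) and goes the same way, with both beyond the scatter. Across the three compounds the widest listed change is a 6.5-fold lower number from compound 1 to compound 3 (0.81 log units; beyond the scatter), with 4-(pyrrolidin-1-yl)piperidin-1-yl in place of 1-methylpiperidin-4-yl, so this position remains open to gains with the rest of the structure held constant. The groups that leave and enter between compound 2 and compound 3 have equal counts of hydrogen-bond donors and acceptors and no net charge, so these counts do not separate the two compounds, and no measurement at hand accounts for the lower number.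

The compounds shown leave open how much of the step belongs to the pyrrolidine ring, which a dimethylamino group or a morpholine ring in its place on the piperidine would test. They also leave open whether a plain piperidin-1-yl on the sulfonyl sulfur keeps any of the gain, and whether the order of these groups holds on a different core.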